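Shifting a Ring Nitrogen: From Compound 2 to Compound 3

The source may hold more compounds than are shown below. What is called first, only, known or untested is meant among the compounds shown, and "the series" means these compounds.

Compound 2 `COc1ccc(C(=O)/C=C/c2cn(-c3ccccc3)nc2-c2cccnc2)c(OC)c1OC` gives in a functional assay on Huh-7 cells (Homo sapiens) for inhibition, read by sulforhodamine B assay, with a stated time of 72 h (a higher number here means a weaker inhibitor, a lower number a stronger inhibitor), a value of 2300 nM, the lowest of the two numbers shown so far, though its nearest neighbour is not separable from it: compound 1 `COc1ccc(C(=O)/C=C/c2cn(-c3ccccc3)nc2-c2ccsc2)c(OC)c1OC` gives 4200 nM, and the step of a 1.8-fold lower number from compound 1 to compound 2 (0.26 log units; within the scatter) stays within the scatter. Compound 3 `COc1ccc(C(=O)/C=C/c2cn(-c3ccccc3)nc2-c2ccncc2)c(OC)c1OC` differs from compound 2 by pyridin-4-yl in place of pyridin-3-yl on an aromatic carbon. Among the measured compounds shown here, no measured step covers this exact change; the only step recorded, a swap of one ring for another at the same place, remained within the scatter, so no step beyond the scatter is expected here. Compound 3 is therefore estimated at 2500 nM, with a range from 1000 nM to 6500 nM. The expected step is a 1.1-fold higher number from compound 2 to compound 3 (0.04 log units; within the scatter).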

Compound 3, half-maximal inhibitory concentration: 3700 nM
For compound 3 the middle estimate is 1.5-fold (0.17 log units) below the measured one; the range from low to high includes it.
By their numbers in this assay, from the lowest: compounds 2, 3 and 1 (each within the scatter of the next).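

With pyridin-4-yl in place of pyridin-3-yl, this assay shows (a 1.6-fold higher number from compound 2 to compound 3 (0.21 log units; within the scatter)), so moving the ring nitrogen within the pyridine ring at this place, next to the ring nitrogen of the five-membered ring, gives no separable change. With pyridin-4-yl in place of thiophen-3-yl, the same assay shows (a 1.1-fold lower number from compound 1 to compound 3 (0.06 log units; within the scatter)), so all three rings at this place now read alike. No evidence bears on these results. Still open, on these data alone, is whether an amine, a carboxylic acid or a longer chain at this place would give a step beyond the scatter.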